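A quinolinyl phosphate ester of a fluorouracil nucleoside

The source may hold more compounds than are shown below. What is called first, only, known or untested is meant among the compounds shown, and "the series" means these compounds.

The series compares phosphate esters of a fluorinated nucleoside in a functional assay on HeLa cells (Homo sapiens) for cytotoxicity, read by MTT assay, with a stated time of 48 h; a lower number here means a stronger inhibitor, a higher number a weaker inhibitor. Compound 1 `O=C(O[C@H]1C[C@H](n2cc(F)c(=O)[nH]c2=O)O[C@@H]1COP(=O)(O)Oc1ccccc1)c1ccccc1` carries a benzoyl group on the sugar hydroxyl and gives 5860 nM. Compound 2 `O=c1[nH]c(=O)n([C@H]2C[C@H](O)[C@@H](COP(=O)(O)Oc3ccccc3)O2)cc1F` has a free hydroxyl there, and compound 2 gives 15200 nM, the highest of the two numbers recorded so far. Among the measured compounds shown here, the only step measured, a 2.6-fold higher number from compound 1 to compound 2 (0.41 log units; beyond the scatter), concerns the hydrogen in place of benzoyl on an oxygen on a saturated carbon, a modest step beyond the scatter.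

Compound 3 `O=c1[nH]c(=O)n([C@H]2C[C@H](O)[C@@H](COP(=O)(O)Oc3ccc4ncccc4c3)O2)cc1F` differs from compound 2 at another place: quinolin-6-yl in place of phenyl on an oxygen. For the measured compounds named here, no measured step touches the substituent on the oxygen bound to phosphorus, so the step from compound 2 sets no expectation for this change, and nothing in the two measured numbers points in either direction. The expected step, a 1.3-fold lower number from compound 2 to compound 3 (0.10 log units; within the scatter), is therefore a small one, most likely inside the scatter. Compound 3 is estimated to give 12000 nM in this assay, within a range from 4000 nM to 40000 nM.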

Compound 3, half-maximal inhibitory concentration: 7300 nM
For compound 3 the middle estimate is 1.6-fold (0.22 log units) above the measured one; the measured number falls inside the stated range.
By their numbers in this assay, from the lowest: compounds 1 and 3 (each within the scatter of the next); then compound 2.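

In this assay, the change to quinolin-6-yl in place of phenyl gives a 2.1-fold lower number from compound 2 to compound 3 (0.32 log units; beyond the scatter), a modest step but the first measured at the oxygen bound to phosphorus. Among the compounds shown here, this shows that the group on that oxygen affects the number, so the free hydroxyl that carries the benzoyl group in compound 1 is no longer the only place on compound 2 where a single change is seen to move it beyond the scatter. The change adds a second six-membered aromatic ring, a ring nitrogen and a hydrogen-bond acceptor all at once, and no measurement bearing on why the number moves is available.

The compounds shown do not separate the contribution of the added ring from that of the nitrogen: a naphthalen-2-yl group would keep two rings of carbon only, whereas a pyridinyl group would keep the nitrogen in a single ring. They also leave open whether a benzoyl group on the sugar oxygen would shift the number in the same direction when quinolin-6-yl sits on the phosphate, since the two changes are seen only separately.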